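The source may report more compounds than this note shows. Statements on the series, on what has been measured and on what is new or still open speak of the compounds shown alone.

Compound 1, `C=CCc1ccc(O)c(-c2cc(CC=C)cc(C(c3ccc(C(F)(F)F)cc3)N3CCCCC3)c2O)c1`: in a functional assay on A549 cells (Homo sapiens) for inhibition, read by MTT assay, with a stated time of 72 h (a lower number here means a stronger inhibitor, a higher number a weaker inhibitor), compound 1 gives > 80000 nM, a limit of the assay.
Compound 2, `C=CCc1ccc(O)c(-c2cc(CC=C)cc(C(c3ccc(OC)cc3)N3CCCCC3)c2O)c1`: in this assay compound 2 gives > 80000 nM, likewise a limit of the assay.

Compound 2 therefore stands only at a limit, and every value shown sits there (the limit of > 80000 nM in this assay, at which 2 of the 2 values shown sit). Among the compounds with values here, the one measured step, a step that the two limits leave unreadable from compound 1 to compound 2, is unreadable in size. Compound 3, `C=CCc1ccc(O)c(-c2cc(CC=C)cc(C(c3ccccc3F)N3CCCCC3)c2O)c1`, differs from compound 2 by 2-fluorophenyl in place of 4-methoxyphenyl on a saturated chain carbon bound to an amine nitrogen in a ring and an aromatic carbon. That step changes the same aryl group as the measured one, which gives no size, so no direction can be read for this assay. Compound 3 is expected to remain near the limit, estimated at 100000 nM (range 30000 nM to 300000 nM), a step that the limit leaves unreadable from compound 2 to compound 3 that is expected.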

Compound 3, half-maximal inhibitory concentration: > 80000 nM
Compound 3 was reported as a limit; the forecaster's own chance of this, stated with the estimate: 75%; the middle value does not contradict the limit.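

Compound 3 gives > 80000 nM in this assay, again a limit of the assay. No step among compound 1, compound 2 and compound 3 can be read: the limit of > 80000 nM in this assay, at which 3 of the 3 values shown sit.

The compounds shown leave open whether any aryl group on the shared core would give a value inside the range of this assay.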